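A few compounds are considered here, and "the series" means these few. Any claim that something is new, unique, unknown or untested is made for them only; others in the source may bear on it.

In a functional assay on HepG2 cells (Homo sapiens) for antiproliferative activity, read by MTT assay, with a stated time of 48 h (on this read-out higher numbers stand for weaker inhibition and lower numbers for stronger inhibition), compound 1 `COc1ccc(-c2ccc3c(c2)C(=O)C(=O)N3Cc2cccc(Cl)c2)cc1` gives 320 nM, compound 2 `COc1ccc(-c2ccc3c(c2)C(=O)C(=O)N3Cc2ccc(Br)cc2)cc1` gives 700 nM, and compound 3 `COc1ccc(CN2C(=O)C(=O)c3cc(-c4cccc(OC)c4)ccc32)cc1` gives 1890 nM, the highest of the three numbers and so the weakest inhibition here. Compound 4 `COc1ccc(CN2C(=O)C(=O)c3cc(-c4ccc(F)c(Cl)c4)ccc32)cc1` is still unmeasured. It carries 3-chloro-4-fluorophenyl in place of 3-methoxyphenyl on an aromatic carbon. Going by the values given here, no measured step changes that place. Among the compounds with values here, the only step available, a 2.2-fold higher number from compound 1 to compound 2 (0.34 log units; beyond the scatter), concerns a different group and is modest, so only a modest step is expected here. Compound 3 stands at the top of the set with 1890 nM, so a lower number seems somewhat more likely, though the data do not settle the direction. The expected change is a 1.7-fold lower number from compound 3 to compound 4 (0.24 log units; within the scatter). For compound 4 the estimated value is 1100 nM, within an expected range of 350 nM to 3000 nM.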

Compound 4, half-maximal inhibitory concentration: > 10000 nM
Compound 4 was reported as a limit; the forecaster's own chance of this, stated with the estimate: 3%; at least 9.0-fold (0.95 log units) between middle value and limit.
By their numbers in this assay, from the lowest: compound 1; then compound 2; then compound 3. At a limit, above all of these: compound 4.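

Going by these compounds alone, this place on the shared core, an aromatic carbon that no earlier step had touched, turns out to matter: in this assay, 3-chloro-4-fluorophenyl in place of 3-methoxyphenyl gives an at least 5.2-fold higher number from compound 3 to compound 4 (0.72 log units; beyond the scatter). Activity here therefore depends on which phenyl group is attached, not only on the group at the ring nitrogen changed between the earlier compounds. Compound 4 stands at a limit of the assay: the limit of > 10000 nM in this assay, at which 1 of the 4 values shown sits.

The change removes the methoxy group and adds chlorine and fluorine together, so their separate contributions cannot be told apart. As far as these compounds go, how an amine or a carboxylic acid on this phenyl ring would behave also stays open.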